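What a 2-methoxyphenyl may do to compound 2

A few compounds are considered here, and "the series" means these few. Any claim that something is new, unique, unknown or untested is made for them only; others in the source may bear on it.

Of the compounds shown here, three have been tested in a physicochemical assay for solubility, measured as kinetic solubility; a higher number here means a more soluble compound, a lower number a less soluble compound. Compound 2 `Cc1n[nH]c(-c2ncc3cccnc3c2O)n1` reads > 250000 nM, which is a limit of the assay and not a number. Compound 3 `O=C(NCc1ccc(Cl)cc1)c1ncc2cccnc2c1O` reads > 250000 nM, also a limit. Compound 1 `Oc1c(-c2nnc(Cc3ccc(Cl)cc3)[nH]2)ncc2cccnc12` gives an actual number, 219000 nM.

Compound 4 `COc1ccccc1-c1ccnc2c(O)c(-c3nc(C)n[nH]3)ncc12` is compound 2 with one change: 2-methoxyphenyl in place of hydrogen on an aromatic carbon, opposite the ring nitrogen. Within the data shown here, no measured pair shows this change, so any forecast is loose. Among the measured compounds shown here, the only numeric guide is compound 1 at 219000 nM. A moderate fall in this assay is expected, beyond the usual scatter, and the estimated step is an at least 1.9-fold lower number from compound 2 to compound 4 (0.28 log units; that floor lies within the scatter). Compound 4 is expected to read about 130000 nM, within an estimated range of 35000 nM to 250000 nM.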

Compound 4, solubility: > 250000 nM
Compound 4 gave a limit, no number (the forecaster's own chance of this, stated with the estimate: 30%); middle value at least 1.9-fold (0.28 log units) away from the limit.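

Compound 2 and compound 4 each give only a limit, not a number, so no step between them can be read in this assay, because both sit at the same ceiling: the limit of > 250000 nM in this assay, at which 3 of the 4 values shown sit.

As far as these compounds go, whether 2-methoxyphenyl in place of hydrogen changes the read-out of this assay at all, and by how much, stays open.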